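Methyl on the saturated ring carbon: compound 3 to compound 4

This account rests on a few compounds, and the source may have more. Where it says the series, first, only, none or still open, it means among the compounds named here.

Working notes on a small set of five-membered ring thiazolidinone-type inhibitors measured in a physicochemical assay for inhibition, with a stated time of 3 min; on this read-out lower numbers stand for stronger inhibition and higher numbers for weaker inhibition. Compound 1 `CC(=C/c1ccccc1)/C=C1\SC(N(C)c2ccc(O)cc2)=NC1=O` gives 3400 nM. Compound 2 `O=C1N=C(Nc2nccs2)S/C1=C1\C(=O)Nc2ccc(Br)cc21` gives 380 nM; the two values show compound 2 as the stronger of the pair. Compound 3 `O=C1CS/C(=N/N=C/c2cccnc2)N1` was run in this assay and gives "not determined" (no result reported), so it has no number to stand on. Compound 4 `CC1S/C(=N/N=C/c2cccnc2)NC1=O` differs from compound 3 by methyl in place of hydrogen on a saturated ring carbon. Among the measured compounds shown here, no step between measured compounds is available for this change, so its size is unknown; with compound 3 unquantified, the expectation for this assay is that compound 4 lies near the weaker end of the measured range, with a wide spread. Compound 4 is expected at 6000 nM, within 800 nM to 40000 nM.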

Compound 4, half-maximal inhibitory concentration: 1960 nM
Beside the measured number, compound 4's estimate is 3.1-fold (0.49 log units) above it; measured number inside the range.
By their numbers in this assay, from the lowest: compound 2; then compounds 4 and 1 (each within the scatter of the next).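

In this assay, among the compounds shown here, compound 3 has no single number, so no step to compound 4 can be read. The compounds shown leave open what methyl in place of hydrogen on the saturated ring carbon does to inhibition. No available evidence bears on this result.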